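The source may report more compounds than this note shows. Statements on the series, on what has been measured and on what is new or still open speak of the compounds shown alone.

Compound 3 `COC(=O)[C@@]1(C)CCC=C2[C@@H]1CC[C@@H](C)[C@]2(C)Cc1c[nH]c2c(C)cccc12` gives 4900 nM in a functional assay on HeLa cells (Homo sapiens) for inhibition, read by sulforhodamine B assay, with a stated time of 48 h (a higher number here means a weaker inhibitor of growth, a lower number a stronger inhibitor of growth), the lowest of the three numbers recorded; compound 2 `COC(=O)[C@@]1(C)CCC=C2[C@@H]1CC[C@@H](C)[C@]2(C)Cc1c[nH]c2ccc(Br)cc12` gives 10000 nM and compound 1 `COC(=O)[C@@]1(C)CCC=C2[C@@H]1CC[C@@H](C)[C@]2(C)Cc1c[nH]c2ccc(C)cc12` gives 14000 nM. Compound 4 `COC(=O)[C@@]1(C)CCC=C2[C@@H]1CC[C@@H](C)[C@]2(C)Cc1c[nH]c2c(Cl)cccc12` differs from compound 3 by chloro in place of methyl on an aromatic carbon. Among the measured compounds shown here, the one measured step that bears on this exchange of a halogen for a methyl is a 1.4-fold lower number from compound 1 to compound 2 (0.15 log units; within the scatter), although that exchange sat at another aromatic carbon of the shared core. It gives no reason to expect more than a small movement, since a halogen in place of a methyl left the number essentially unchanged there. Compound 4 is therefore expected to give 4500 nM in this assay, within a range of 2000 nM to 11000 nM, an estimated step of a 1.1-fold lower number from compound 3 to compound 4 (0.04 log units; within the scatter) that would lie within the scatter.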

Compound 4, concentration for 50% growth inhibition: 14000 nM
Estimate against measurement, compound 4: 3.1-fold (0.49 log units) below; the whole stated range lies below it.
By their numbers in this assay, from the lowest: compound 3; then compounds 2, 1 and 4 (each within the scatter of the next).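

In this assay, chloro in place of methyl on this aromatic carbon gives a 2.9-fold higher number from compound 3 to compound 4 (0.46 log units; beyond the scatter) and so moves the number beyond the scatter, whereas bromo in place of methyl at the other aromatic carbon gave a 1.4-fold lower number from compound 1 to compound 2 (0.15 log units; within the scatter) within it. A halogen for a methyl is therefore not a neutral exchange everywhere on the shared core, and the outcome differs with the place or the halogen. Nothing measured here accounts for this difference. Going by these compounds, whether fluoro, methoxy or an amine on this carbon would match the methyl of compound 3 stays open.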